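Moving the trifluoromethyl group on a pyridine-linked diol scaffold

The compounds below may be only part of what the source reports. "The series", "measured", "known", "first", "only" and "open" are said of these compounds alone.

Compound 1 `Oc1ccc(-c2cc(-c3cccc(C(F)(F)F)c3)cc(-c3ccccc3O)n2)cc1` was measured in a functional assay on HCT-15 cells (Homo sapiens) for inhibition; on this read-out lower numbers stand for stronger inhibition and higher numbers for weaker inhibition. In this assay compound 1 returns only a limit of the assay, > 50000 nM. Compound 2 `Oc1ccc(-c2cc(-c3ccc(C(F)(F)F)cc3)cc(-c3ccccc3O)n2)cc1` differs from it by 4-(trifluoromethyl)phenyl in place of 3-(trifluoromethyl)phenyl on an aromatic carbon. In this assay compound 2 likewise returns only a limit, > 50000 nM. The step that the two limits leave unreadable from compound 1 to compound 2 is therefore not readable, because of the limit of > 50000 nM in this assay, at which 2 of the 3 values shown sit. Compound 3 `Oc1cccc(-c2cc(-c3cccc(C(F)(F)F)c3)cc(-c3cccc(O)c3)n2)c1` carries a different core; how its core differs from that of compound 1 is not broken down here. In this assay, going by the values given here, compound 3 gives 13600 nM, the only number among the three values.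

Compound 4 `Oc1cccc(-c2cc(-c3ccc(C(F)(F)F)cc3)cc(-c3cccc(O)c3)n2)c1` has not yet been measured. It differs from compound 3 by 4-(trifluoromethyl)phenyl in place of 3-(trifluoromethyl)phenyl on an aromatic carbon. This is the same kind of change as that from compound 1 to compound 2, but the surroundings differ: in compound 3 the place is meta to two 3-hydroxyphenyl groups, whereas in compound 1 it is meta to a 2-hydroxyphenyl group and meta to a 4-hydroxyphenyl group. With the earlier step unreadable, compound 4 is expected to stay close to compound 3, an estimated step of a 1.2-fold higher number from compound 3 to compound 4 (0.07 log units; within the scatter). Compound 4 is estimated at 16000 nM, between 5000 nM and 50000 nM.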

Compound 4, half-maximal inhibitory concentration: > 50000 nM
Compound 4 gave a limit, no number; the forecaster's own chance of this, stated with the estimate: 30%; middle value at least 3.1-fold (0.49 log units) from the limit.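

In this assay compound 4 gives > 50000 nM, which is a limit of the assay and not a number. On the core of compound 3, the change from 3-(trifluoromethyl)phenyl to 4-(trifluoromethyl)phenyl still reads as an at least 3.6-fold higher number from compound 3 to compound 4 (0.56 log units; beyond the scatter), although its full size remains unfixed. This does not show that the change acts in the same way on the core of compound 1: the step between compound 1 and compound 2 cannot be read, so the change can be said neither to carry over between the cores nor to fail to, because the values pile up at one ceiling: the limit of > 50000 nM in this assay, at which 3 of the 4 values shown sit.

Among these compounds only compound 3 gives a number, so nothing shows how far either core could move towards stronger inhibition. As far as these compounds go, whether an amine or a carboxylic acid in place of the trifluoromethyl group would keep, strengthen or lose the inhibition seen with compound 3 stays open.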